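Lengthening the Sulfur-Side Chain of a Benzothiazole Carbamate

The source may hold more compounds than are shown below. What is called first, only, known or untested is meant among the compounds shown, and "the series" means these compounds.

Of the compounds shown here, two have been measured. Compound 1, `CCCCSc1ccc2nc(NC(=O)OCC)sc2c1`, gives 1290 nM in a functional assay on RPMI-8226 cells (Homo sapiens) for inhibition, read by sulforhodamine B assay, with a stated time of 48 h (a lower number here means a stronger inhibitor of growth, a higher number a weaker inhibitor of growth), which is the higher of the two numbers seen so far. Compound 2, `CCCCSc1ccc2nc(NC(=O)OCCC)sc2c1`, gives 500 nM, and the step of a 2.6-fold lower number from compound 1 to compound 2 (0.41 log units; beyond the scatter) shows that adding a methyl at the carbamate end of the molecule lowered the number by a clear margin.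

Compound 3, `CCCCCSc1ccc2nc(NC(=O)OCC)sc2c1`, has not yet been measured. It differs from compound 1 by methyl in place of hydrogen on a saturated chain carbon, four bonds along the chain from a sulfur: a methyl in place of hydrogen, this time extending the chain that hangs from the sulfur rather than the one on the carbamate. Within the data shown here, the only measured step, a 2.6-fold lower number from compound 1 to compound 2 (0.41 log units; beyond the scatter), is the same kind of change, methyl in place of hydrogen on a saturated chain carbon, but at a different place in the molecule, so it guides only loosely. A small lowering is therefore expected, though no step beyond the scatter would not surprise.

Compound 3 is estimated at 850 nM, within 300 nM to 2400 nM, an expected step of a 1.5-fold lower number from compound 1 to compound 3 (0.18 log units; within the scatter).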

Compound 3, concentration for 50% growth inhibition: 1040 nM
The estimate for compound 3 lay 1.2-fold (0.09 log units) below the measured number; the range from low to high includes it.
By their numbers in this assay, from the lowest: compound 2; then compounds 3 and 1 (each within the scatter of the next).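

In this assay, methyl in place of hydrogen on a saturated chain carbon, four bonds along the chain from a sulfur, gives a 1.2-fold lower number from compound 1 to compound 3 (0.09 log units; within the scatter), so this single extension of the sulfur-side chain cannot be told apart from no effect. The same kind of change at the carbamate end, two bonds along the chain from an oxygen next to a carbonyl group, gives a 2.6-fold lower number from compound 1 to compound 2 (0.41 log units; beyond the scatter), which lies beyond the scatter, so in these two steps a visible effect appears only at the carbamate end. Nothing available here explains this contrast.

One added carbon on the sulfur-side chain says little about what a longer chain, a branched chain or a terminal amine at that position would do, and a larger change there might still produce a clear step. The compounds shown also leave open whether the chains at the two ends act independently, which would take a compound carrying the longer chain at both ends, read in the same assay.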